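The source may hold more compounds than are shown below. What is called first, only, known or untested is meant among the compounds shown, and "the series" means these compounds.

Measured in a functional assay on U-373MG ATCC cells for cytotoxicity against U373 MG (Homo sapiens), read by colorimetric assay and MTT assay; on this read-out higher numbers stand for weaker inhibition and lower numbers for stronger inhibition:

Compound 1 `COc1cc(OC)c2cc(-c3ccc(OCc4ccccc4)cc3)c(O)nc2c1`: 10000 nM
Compound 2 `CCOC(=O)Cn1c(=O)c(-c2ccc(OC)cc2)cc2c(OC)cc(OC)cc21`: 10000 nM

In this assay, compound 2 gives 10000 nM and stands level with compound 1, with no difference between them at the digits reported. Compound 3 `COc1ccc(-c2cc3c(OC)cc(OC)cc3n(CCC(=O)OCc3ccccc3)c2=O)cc1` has not yet been measured. It keeps the core of compound 2 and differs in a single place: (benzyloxycarbonyl)methyl in place of ethoxycarbonyl on a saturated chain carbon bound to an aromatic nitrogen. In words, (benzyloxycarbonyl)methyl stands in place of ethoxycarbonyl on a saturated chain carbon bound to an aromatic nitrogen.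

Within the data shown here, no measured pair of compounds differs in one place, so the data give no direct reading of what such a change does. Among the measured compounds shown here, the only guide is the level pair: compound 1 at 10000 nM and compound 2 at 10000 nM. On that basis no step beyond the scatter is expected in this assay, and no direction is favoured, although two compounds are a thin basis. The expected change is no change at the digits printed from compound 2 to compound 3 (within the scatter). Compound 3 is estimated at about 10000 nM, with an expected range from 4000 nM to 20000 nM.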

Compound 3, half-maximal inhibitory concentration: 10000 nM
For compound 3 middle estimate and measured number coincide at the digits printed; low and high end bracket the measured number.
By their numbers in this assay, from the lowest: compounds 1, 2 and 3 (each within the scatter of the next).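

In this assay, putting (benzyloxycarbonyl)methyl in place of ethoxycarbonyl on a saturated chain carbon bound to an aromatic nitrogen gives no change at the digits printed from compound 2 to compound 3 (within the scatter), the first reading of a change in one place among these compounds. The entering group adds a six-membered aromatic ring of carbon only, while its counts of hydrogen-bond donors and acceptors match those of the group it replaces, and this larger group does not separate the two compounds on this read-out. No measurement shown here explains this result.

The compounds shown leave open whether a carboxylic acid or an amine on the same saturated chain carbon would read differently from compound 3 at 10000 nM. Also open is whether any change to the shared core would move a compound away from this level, as all the compounds shown so far read alike in this assay.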